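A few compounds are considered here, and "the series" means these few. Any claim that something is new, unique, unknown or untested is made for them only; others in the source may bear on it.

Measured in a functional assay on the whole organism with Mus musculus as the target (a higher number here means that more compound is needed for the effect, a lower number that less compound is needed), so far:
- Compound 1 `Cc1c(C)c2c(c(C)c1N)CC(C)(CSc1nccn1C)O2` gives 37.1 mg/kg
- Compound 2 `CCCSCC1(C)Cc2c(C)c(N)c(C)c(C)c2O1` gives 24.6 mg/kg
- Compound 3 `Cc1c(C)c2c(c(C)c1N)CC(C)(CSCCO)O2` gives > 50 mg/kg as a limit, not a number

Compound 3 stands at the limit of > 50 mg/kg in this assay, at which 1 of the 3 values shown sits, and has no exact value. Compound 4 `COCC1(C)Cc2c(C)c(N)c(C)c(C)c2O1` is unmeasured and carries methoxy in place of (2-hydroxyethyl)sulfanyl on a saturated chain carbon bound to a saturated ring carbon in the structure. The measured steps, an at least 1.3-fold higher number from compound 1 to compound 3 (0.12 log units; that floor lies within the scatter) and an at least 2.0-fold higher number from compound 2 to compound 3 (0.30 log units; that floor lies within the scatter), only exchange groups on a sulfur, so they bear on this change indirectly. Neither shows a step beyond the scatter. What is expected is an at least 1.2-fold lower number from compound 3 to compound 4 (0.09 log units; that floor lies within the scatter) in this assay, with no clear step beyond the scatter. The estimated value for compound 4 is 40 mg/kg, with an expected range from 18 mg/kg to 90 mg/kg as its ends.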

Compound 4, dose for 50% inhibition: 20.1 mg/kg
Estimate against measurement, compound 4: 2.0-fold (0.30 log units) above; low and high end bracket the measured number.
By their numbers in this assay, from the lowest: compounds 4, 2 and 1 (each within the scatter of the next). At a limit, above all of these: compound 3.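

Compound 3 carries a limit, not a number: the limit of > 50 mg/kg in this assay, at which 1 of the 4 values shown sits. Even so, methoxy in place of (2-hydroxyethyl)sulfanyl on this saturated chain carbon gives the first step beyond the scatter, an at least 2.4-fold lower number from compound 3 to compound 4 (0.39 log units; beyond the scatter), showing that this assay needs no sulfur at this place. Methoxy in place of the other two sulfur groups gives a 1.2-fold lower number from compound 2 to compound 4 (0.09 log units; within the scatter) and a 1.8-fold lower number from compound 1 to compound 4 (0.27 log units; within the scatter), so compound 4 cannot be told apart from either. The compounds shown leave open whether an amine or a carboxylic acid on this carbon would keep the effect, and whether a longer chain ending in an ether oxygen would match methoxy.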